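The source may hold more compounds than are shown below. What is called first, only, known or untested is meant among the compounds shown, and "the series" means these compounds.

Working notes on the series. Compound 1 `Nc1ccccc1NC(=O)c1ccc(-c2nnc(Cc3cccc4ccccc34)o2)cc1` carries a 2-aminophenyl amide at the end of the shared core. In an assay on isolated protein for inhibition of histone deacetylase 4 (Homo sapiens), read by fluorescence, with a stated time of 15 min (on this read-out higher numbers stand for weaker inhibition and lower numbers for stronger inhibition), compound 1 reaches only the limit of > 20000 nM, so no number is known for it; the limit of > 20000 nM in this assay, at which 1 of the 2 values shown sits, records this. Compound 2 `O=C(/C=C/c1ccc(-c2nnc(Cc3c[nH]c4ccccc34)o2)cc1)NO`, built on a different framework but ending in a hydroxycarbamoyl group, gives 15200 nM in this assay, a number rather than a limit. For the measured compounds named here, no two measured compounds differ in a single place, so no measured step is available. Compound 3 `O=C(NO)c1ccc(-c2nnc(Cc3cccc4ccccc34)o2)cc1` is the next analogue: hydroxy in place of 2-aminophenyl on an amide-type nitrogen. Compound 3 is expected to move toward stronger inhibition, by a step of about an at least 2.5-fold lower number from compound 1 to compound 3 (0.39 log units; beyond the scatter), since compound 2, which shares the hydroxycarbamoyl end, gives 15200 nM. Compound 3 is therefore estimated at 8000 nM, with a likely range from 2000 nM to 25000 nM.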

Compound 3, half-maximal inhibitory concentration: > 20000 nM
Compound 3 was reported as a limit; the forecaster's own chance of this, stated with the estimate: 25%; at least 2.5-fold (0.39 log units) between middle value and limit.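

For the compounds shown here, compound 1 and compound 3 both give only a limit in this assay, so no step between them can be read: the limit of > 20000 nM in this assay, at which 2 of the 3 values shown sit. As far as these compounds go, whether hydroxy in place of 2-aminophenyl on an amide-type nitrogen changes inhibition at all remains open.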